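A few compounds are considered here, and "the series" means these few. Any claim that something is new, unique, unknown or untested is made for them only; others in the source may bear on it.

Measured in a functional assay on HepG2 cells (Homo sapiens) for inhibition, read by MTT assay, with a stated time of 24 h; on this read-out lower numbers stand for stronger inhibition and higher numbers for weaker inhibition:
compound 1 `CC1(C)[C@H]2CC[C@]1(C)N(Cc1cn(-c3cccc(C#N)c3)nn1)C(=O)C2` gives 40 nM
compound 2 `CC1(C)[C@H]2CC[C@]1(C)N(Cc1cn(-c3cccc(Cl)c3)nn1)C(=O)C2` gives 60 nM
compound 3 `COc1ccccc1-n1cc(CN2C(=O)C[C@@H]3CC[C@@]2(C)C3(C)C)nn1` gives 110 nM

Compound 3 stands at 110 nM on these numbers. The nearest step to it is a 1.8-fold higher number from compound 2 to compound 3 (0.26 log units; within the scatter) and the furthest is a 2.8-fold higher number from compound 1 to compound 3 (0.44 log units; beyond the scatter) in this small set.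

Next in view is compound 4 `Cc1ccc(-n2cc(CN3C(=O)C[C@@H]4CC[C@@]3(C)C4(C)C)nn2)cc1`, not yet measured. The change is 4-methylphenyl in place of 2-methoxyphenyl on an aromatic nitrogen with 4-methylphenyl in place of 2-methoxyphenyl on an aromatic nitrogen.

Going by the values given here, the steps that bear on this are those that swap the group on that same nitrogen. Besides the two above, the third is a 1.5-fold higher number from compound 1 to compound 2 (0.18 log units; within the scatter) and none of the three is large. Among the compounds with values here, no measured compound carries 4-methylphenyl, so the data give no direct reading for it. Only a small move is therefore expected, none beyond the scatter, leaning slightly toward compound 1 at 40 nM and compound 2 at 60 nM in direction. The expected step is a 1.4-fold lower number from compound 3 to compound 4 (0.14 log units; within the scatter) in this estimate. In this assay compound 4 is estimated at 80 nM with an expected range of 30 nM to 220 nM for the measurement.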

Compound 4, half-maximal inhibitory concentration: 480 nM
For compound 4 the middle estimate is 6.0-fold (0.78 log units) below the measured one, and the stated range ends below it.
By their numbers in this assay, from the lowest: compounds 1, 2 and 3 (each within the scatter of the next, the first and the last beyond it); then compound 4.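

In this assay, going by these compounds alone, the group on this aromatic nitrogen proves able to move the number well beyond the scatter: the change gives a 4.4-fold higher number from compound 3 to compound 4 (0.64 log units; beyond the scatter), and the same group compares as an 8.0-fold higher number from compound 2 to compound 4 (0.90 log units; beyond the scatter) and a 12-fold higher number from compound 1 to compound 4 (1.08 log units; beyond the scatter), the last a large step, whereas the widest step among the earlier compounds was a 2.8-fold higher number from compound 1 to compound 3 (0.44 log units; beyond the scatter). Compound 4 therefore has the weakest inhibition of the four, and the earlier near-equivalence of compounds 2 and 3 does not extend to every substituted phenyl group at this position. The step to compound 4 exchanges 2-methoxyphenyl, with 8 heavy atoms and 1 hydrogen-bond acceptor, for 4-methylphenyl, with 7 heavy atoms and 0 hydrogen-bond acceptors, and no measurement at hand accounts for the change in the number.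

Since the substituent and its place on the phenyl ring change together in this step, the two remain unseparated; 3-methylphenyl, 2-methylphenyl and 4-cyanophenyl on the same nitrogen would pull them apart. Also open, going by these compounds, is how an amine or a carboxylic acid on the phenyl ring, or a benzyl group in place of the phenyl ring, would read out in this assay.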